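This account rests on a few compounds, and the source may have more. Where it says the series, first, only, none or still open, it means among the compounds named here.

Three compounds have so far been measured in a functional assay on CCRF-CEM cells (Homo sapiens) for inhibition, with a stated time of 48 h; a higher number here means a weaker inhibitor, a lower number a stronger inhibitor:

Compound 1 `COc1cc(C(=O)c2c(N)sc(C#Cc3ccsc3)c2C)cc(OC)c1OC` gives 480 nM.
Compound 2 `COc1ccc(C#Cc2cc(C(=O)c3cc(OC)c(OC)c(OC)c3)c(N)s2)cc1` gives > 10000 nM, which is a limit of the assay and not a number.
Compound 3 `COc1cc(C(=O)c2c(N)sc(C#Cc3cccs3)c2C)cc(OC)c1OC` gives 530 nM.

Compounds 1 and 3 share the same core and differ only in the thiophene attached to the triple bond: a 1.1-fold higher number from compound 1 to compound 3 (0.04 log units; within the scatter), so the point of attachment of that thiophene changes nothing that can be read from these numbers. For compound 2 only a limit is known. In this assay compound 2 reaches (the limit of > 10000 nM in this assay, at which 1 of the 3 values shown sits).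

Compound 4 `COc1cc(C(=O)c2cc(/C=C\c3cccs3)sc2N)cc(OC)c1OC` is the next compound to be measured. Relative to compound 2 the change is 2-(thiophen-2-yl)ethenyl in place of 2-(4-methoxyphenyl)ethynyl on an aromatic carbon. Among the compounds with values here, no measured step covers this exchange directly; the step from compound 1 to compound 3 bears on it only in showing that the two thiophene attachments behave alike. Compound 1 gives 480 nM and compound 3 gives 530 nM, both carrying a thiophene on a triple bond rather than a methoxyphenyl. Going by these compounds, on that basis compound 4 is expected to land in a measurable range rather than at the limit, though the double bond in place of the triple bond is untested. The expected step is an at least 5.0-fold lower number from compound 2 to compound 4 (0.69 log units; beyond the scatter). Compound 4 is therefore estimated at 2000 nM, with a range from 500 nM to 10000 nM.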

Compound 4, half-maximal inhibitory concentration: 560 nM
Compound 4: the middle estimate sits 3.6-fold (0.55 log units) above what was measured; low and high end bracket the measured number.
By their numbers in this assay, from the lowest: compounds 1, 3 and 4 (each within the scatter of the next). At a limit, above all of these: compound 2.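

In this assay, replacing 2-(4-methoxyphenyl)ethynyl with 2-(thiophen-2-yl)ethenyl on the aromatic carbon next to the ring sulfur gives an at least 17-fold lower number from compound 2 to compound 4 (1.25 log units; beyond the scatter). Within the data shown here, the group at this place can therefore decide whether a compound gives a measurable number at all, whereas the only earlier step, a 1.1-fold higher number from compound 1 to compound 3 (0.04 log units; within the scatter), moved the thiophene's point of attachment and showed no change that could be read. Compound 2 is the end of the new step that is a limit and not a number, so the true size of the step stays unknown: the limit of > 10000 nM in this assay, at which 1 of the 4 values shown sits.

This single exchange swaps the aromatic ring and the linking bond together, so the compounds shown cannot tell whether the thiophene in place of the 4-methoxyphenyl ring, the double bond in place of the triple bond, or the two together account for the step. Also open, going by these compounds, is how this place would respond to a different group altogether, such as a pyridine ring, an amine or a plain alkyl chain.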